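Ethyl at the core carbon of a triazole-linked series

A few compounds are considered here, and "the series" means these few. Any claim that something is new, unique, unknown or untested is made for them only; others in the source may bear on it.

Measured so far:
compound 1 `CCCCCCCCCCn1cc(Cn2cnc3nc(-c4ccccc4)cc(C(F)(F)F)c3c2=O)nn1` — 8.16 ug/mL
compound 2 `CCc1nc2nc(-c3ccccc3)cc(C(F)(F)F)c2c(=O)n1Cc1cn(CCC(F)(F)C(F)(F)C(F)(F)C(F)(F)C(F)(F)C(F)(F)F)nn1` — > 200 ug/mL

Among the compounds with values here, in a functional assay on U-937 cells (Homo sapiens) for cytotoxicity, read by MTT assay, with a stated time of 24 h (on this read-out lower numbers stand for stronger inhibition and higher numbers for weaker inhibition), compound 1 gives 8.16 ug/mL, the only numerical value in the set. For compound 2 this assay reports only a limit, > 200 ug/mL; here (the limit of > 200 ug/mL in this assay, at which 1 of the 2 values shown sits). Compound 3 `CCCCCCCCCCn1cc(Cn2c(CC)nc3nc(-c4ccccc4)cc(C(F)(F)F)c3c2=O)nn1` is not yet measured. It differs from compound 1 by ethyl in place of hydrogen on an aromatic carbon. Within the data shown here, no measured pair isolates this change, so its size is open; a modest weakening beyond the scatter is expected rather than a gain. The estimate a 2.5-fold higher number from compound 1 to compound 3 (0.39 log units; beyond the scatter) places compound 3 at 20 ug/mL, within 6 ug/mL to 80 ug/mL.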

Compound 3, half-maximal inhibitory concentration: 17.8 ug/mL
Estimate against measurement, compound 3: 1.1-fold (0.05 log units) above; measured number inside the range.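

In this assay ethyl in place of hydrogen on an aromatic carbon, between two ring nitrogen atoms, gives a 2.2-fold higher number from compound 1 to compound 3 (0.34 log units; beyond the scatter) and so carries a modest cost at this position. Compound 2 gives > 200 ug/mL as a limit and not a number, and it differs from compound 1 in more than one place, so only the new pair isolates this change. Nothing shown bears on why the step has this size. As far as these compounds go, whether a methyl, a propyl or an amine at this carbon would cost less or more stays open.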